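Amide cap variation on a shared chalcone-type core

The compounds below may be only part of what the source reports. "The series", "measured", "known", "first", "only" and "open" are said of these compounds alone.

Three amides on one core have been measured in a functional assay on SiHa cells (Homo sapiens) for inhibition; a lower number here means a stronger inhibitor, a higher number a weaker inhibitor. Compound 1 `COc1cc(/C=C/C(=O)c2cccc(NC(=O)c3ccc(Cl)c(Cl)c3)c2)ccc1O` gives 25.3 ug/mL, compound 2 `COc1cc(/C=C/C(=O)c2cccc(NC(=O)C(C)C)c2)ccc1O` gives 5.96 ug/mL, and compound 3 `COc1cc(/C=C/C(=O)c2cccc(NC(=O)c3ccccc3)c2)ccc1O` gives 4.57 ug/mL. Compound 2 holds the second highest of the three numbers: its step to compound 3 is a 1.3-fold lower number from compound 2 to compound 3 (0.12 log units; within the scatter), while the step from compound 1 is a 4.2-fold lower number from compound 1 to compound 2 (0.63 log units; beyond the scatter). Compound 4 `COc1cc(/C=C/C(=O)c2cccc(NC(=O)c3ccc(Cl)cc3)c2)ccc1O` carries 4-chlorophenyl in place of isopropyl on a carbonyl carbon. For the measured compounds named here, two measured steps bear on this change: a 1.3-fold lower number from compound 2 to compound 3 (0.12 log units; within the scatter) and a 5.5-fold lower number from compound 1 to compound 3 (0.74 log units; beyond the scatter), where the 3,4-dichlorophenyl amide sits clearly higher than the phenyl amide. A 4-chlorophenyl amide is expected to fall between those two. For compound 4 the expected step of a 1.3-fold higher number from compound 2 to compound 4 (0.13 log units; within the scatter) points to a somewhat higher number, with an estimated value of 8 ug/mL and a range of 3.5 ug/mL to 18 ug/mL.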

Compound 4, half-maximal inhibitory concentration: 2.3 ug/mL
Estimate against measurement, compound 4: 3.5-fold (0.54 log units) above; the whole stated range lies above it.
By their numbers in this assay, from the lowest: compounds 4, 3 and 2 (each within the scatter of the next, the first and the last beyond it); then compound 1.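

In this assay, a 2.0-fold lower number from compound 3 to compound 4 (0.30 log units; within the scatter) stays within the scatter, so adding a chloro to the phenyl cap leaves the number unmoved on this evidence. The second chloro matters far more: an 11-fold lower number from compound 1 to compound 4 (1.04 log units; beyond the scatter) is the largest step in the series, and it separates the 3,4-dichlorophenyl cap from the 4-chlorophenyl cap. Replacing isopropyl also counts here, as a 2.6-fold lower number from compound 2 to compound 4 (0.41 log units; beyond the scatter) lies beyond the scatter, whereas the phenyl cap of compound 3 does not separate from isopropyl.

Going by these compounds, whether a 3-chlorophenyl cap would behave like the 3,4-dichlorophenyl cap or the 4-chlorophenyl cap remains open, as does the reading for a 4-methoxyphenyl cap or a longer chain on this carbonyl carbon. No evidence at hand accounts for these steps.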